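The source may report more compounds than this note shows. Statements on the series, on what has been measured and on what is new or still open speak of the compounds shown alone.

Compound 3 `CC(C)[C@H](NC(=O)COc1cccc2ccccc12)C(=O)N[C@@H](CC(=O)O)C(=O)COc1cc(F)ccc1F` is one of three close relatives that share a core and differ only in the group on an oxygen on a saturated carbon. In a functional assay on Jurkat cells (Homo sapiens) (a higher number here means a weaker inhibitor, a lower number a stronger inhibitor), compound 3 gives only a limit, > 100000 nM. Compound 1 `CC(C)[C@H](NC(=O)COc1cccc2ccccc12)C(=O)N[C@@H](CC(=O)O)C(=O)COc1ccccc1C(F)(F)F` likewise reaches only the limit > 100000 nM in this assay. Compound 2 `CC(C)[C@H](NC(=O)COc1cccc2ccccc12)C(=O)N[C@@H](CC(=O)O)C(=O)COc1ccc(C(N)=O)cc1` also stops at the limit > 100000 nM in this assay. So the steps a step that the two limits leave unreadable from compound 1 to compound 2, a step that the two limits leave unreadable from compound 1 to compound 3 and a step that the two limits leave unreadable from compound 2 to compound 3 cannot be read, because of the limit of > 100000 nM in this assay, at which 3 of the 3 values shown sit. Compound 4 `CC(C)[C@H](NC(=O)COc1cccc2ccccc12)C(=O)N[C@@H](CC(=O)O)C(=O)COc1c(Cl)cccc1Cl` differs from compound 3 in one place: 2,6-dichlorophenyl in place of 2,5-difluorophenyl on an oxygen on a saturated carbon. Among the compounds with values here, no measured step shows any of the three groups moving this series away from the limit, so compound 4 is expected to stay there as well, with an estimated step that the limit leaves unreadable from compound 3 to compound 4. For compound 4 the estimate is 150000 nM, within 30000 nM to 1000000 nM.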

Compound 4, half-maximal inhibitory concentration: 3000 nM
Compound 4: the middle estimate sits 50-fold (1.70 log units) above what was measured; measured number outside the range, below it.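

This position is not indifferent to its group: in this assay, 2,6-dichlorophenyl on the oxygen gives an at least 33-fold lower number from compound 3 to compound 4 (1.52 log units; beyond the scatter), and the same change gives an at least 33-fold lower number from compound 2 to compound 4 (1.52 log units; beyond the scatter) and an at least 33-fold lower number from compound 1 to compound 4 (1.52 log units; beyond the scatter). Compound 4 is therefore the first member of this series to give a readable value, while the others remain at a limit of the assay: the limit of > 100000 nM in this assay, at which 3 of the 4 values shown sit.

From the compounds shown here alone, what stays open is whether the chlorine atoms or their placement on the ring accounts for the drop. A 2,6-difluorophenyl group and a 2,5-dichlorophenyl group would separate these two possibilities.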